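Stereochemical series: inverting the amine-bearing centre of compound 3

The compounds below may be only part of what the source reports. "The series", "measured", "known", "first", "only" and "open" are said of these compounds alone.

For the measured compounds named here, compound 3 `CCCCCCCCCCCC(=O)N[C@H](CO)C[C@H](O)c1ccccc1` sits second highest of the three numbers so far: in an assay on isolated protein for binding affinity to ceramide transfer protein (Homo sapiens), read by TR-FRET, with stated times of 30 min and 18 h (a higher number here means that more compound is needed for the effect, a lower number that less compound is needed), compound 3 gives 25000 nM, close to compound 1 `CCCCCCCCCCCC(=O)N[C@@H](CO)C[C@@H](O)c1ccccc1`, which in this assay gives 22000 nM, while compound 2 `CCCCCCCCCCCC(=O)N[C@H](CO)C[C@@H](O)c1ccccc1` gives 159000 nM. Compound 4 `CCCCCCCCCCCC(=O)N[C@@H](CO)C[C@H](O)c1ccccc1` is next; (the two compounds have the same atoms and bonds and differ only in configuration as drawn: 1 of 2 stereo elements differ; a stereocentre at a saturated chain carbon is drawn S in compound 3 and R in compound 4). The step of a 7.2-fold higher number from compound 1 to compound 2 (0.86 log units; beyond the scatter) inverts the same amine-bearing centre and bears directly on this change; the step of a 1.1-fold higher number from compound 1 to compound 3 (0.06 log units; within the scatter) shows that inverting both centres together changes little, and a 6.4-fold lower number from compound 2 to compound 3 (0.80 log units; beyond the scatter) is the hydroxyl-centre inversion. A rise of roughly the size seen in a 7.2-fold higher number from compound 1 to compound 2 (0.86 log units; beyond the scatter) is therefore expected, so the step of a 6.0-fold higher number from compound 3 to compound 4 (0.78 log units; beyond the scatter) is estimated upward. Compound 4 is expected to give about 150000 nM, within 45000 nM to 450000 nM.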

Compound 4, half-maximal effective concentration: 4000 nM
For compound 4 the middle estimate is 38-fold (1.57 log units) above the measured one, outside the stated range (below it).
By their numbers in this assay, from the lowest: compound 4; then compounds 1 and 3 (each within the scatter of the next); then compound 2.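

In this assay, a 6.3-fold lower number from compound 3 to compound 4 (0.80 log units; beyond the scatter) shows that the amine-bearing centre drawn R gives the lower number under either hydroxyl configuration, the same preference as between compounds 1 and 2. With a 5.5-fold lower number from compound 1 to compound 4 (0.74 log units; beyond the scatter), the hydroxyl centre drawn S likewise gives the lower number under either amine-bearing configuration. The two inversions therefore run in one direction in a 40-fold lower number from compound 2 to compound 4 (1.60 log units; beyond the scatter), leaving compound 4 lowest of the four. Open, going by these compounds, is whether this order of configurations holds with a longer chain, or with a carboxylic acid on the shared core.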